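Ring Nitrogen Substituent Variation in a Naphthyl Chromene Series

A few compounds are considered here, and "the series" means these few. Any claim that something is new, unique, unknown or untested is made for them only; others in the source may bear on it.

Measured compounds:
compound 1 `CO[C@@]12CCN(C)C[C@H]1[C@H](c1ccc3ccccc3c1)C(C#N)=C(N)O2` — 24200 nM
compound 2 `CCN1CC[C@@]2(OC)OC(N)=C(C#N)[C@@H](c3ccc4ccccc4c3)[C@@H]2C1` — 28300 nM

Compound 1 `CO[C@@]12CCN(C)C[C@H]1[C@H](c1ccc3ccccc3c1)C(C#N)=C(N)O2` and compound 2 `CCN1CC[C@@]2(OC)OC(N)=C(C#N)[C@@H](c3ccc4ccccc4c3)[C@@H]2C1` share one core and differ only at the saturated chain carbon bound to the amine nitrogen in the ring. In a functional assay on trachea (Cavia porcellus) (on this read-out higher numbers stand for weaker inhibition and lower numbers for stronger inhibition), compound 1 gives 24200 nM, and compound 2 gives 28300 nM. The step of a 1.2-fold higher number from compound 1 to compound 2 (0.07 log units; within the scatter) is the only measured one, and it does not separate the two compounds. Compound 2 therefore stands with the higher of the two numbers, but within the scatter of compound 1.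

Compound 3 `CO[C@@]12CCN(Cc3ccccc3)C[C@H]1[C@H](c1ccc3ccccc3c1)C(C#N)=C(N)O2` has not yet been measured. It differs from compound 2 by phenyl in place of methyl on a saturated chain carbon bound to an amine nitrogen in a ring. Among the measured compounds shown here, the one measured step at this place, a 1.2-fold higher number from compound 1 to compound 2 (0.07 log units; within the scatter), was small, so there is no measured ground to expect a change beyond the scatter from a larger group here, though the entering phenyl is a larger change than that step covered. Compound 3 is thus expected to give about 25000 nM, within 8000 nM to 80000 nM, a step of a 1.1-fold lower number from compound 2 to compound 3 (0.05 log units; within the scatter) that is estimated to stay near the values of compound 2.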

Compound 3, half-maximal inhibitory concentration: 23400 nM
Compound 3: the middle estimate sits 1.1-fold (0.03 log units) above what was measured; the measured number falls inside the stated range.
By their numbers in this assay, from the lowest: compounds 3, 1 and 2 (each within the scatter of the next).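

In this assay the step of a 1.2-fold lower number from compound 2 to compound 3 (0.08 log units; within the scatter) comes with phenyl in place of methyl on the saturated chain carbon bound to the amine nitrogen in the ring, and the step of a 1.0-fold lower number from compound 1 to compound 3 (0.01 log units; within the scatter) comes with phenyl in place of hydrogen at the same place. The earlier pair covered only methyl in place of hydrogen, whereas these steps bring in one six-membered aromatic ring of carbon only, and the numbers of the three compounds still cannot be told apart. At this place, then, going from ethyl to benzyl on the ring nitrogen leaves the read-out within the scatter, just as the smaller change did. Nothing at hand bears on why the numbers stay together.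

The compounds shown leave open whether an amine, a carboxylic acid or a longer chain at this place would move the number beyond the scatter. They also leave open what any change elsewhere on the shared core would do, for the three compounds differ only at this one place.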